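Removing the acetyl from compound 1

A few compounds are considered here, and "the series" means these few. Any claim that something is new, unique, unknown or untested is made for them only; others in the source may bear on it.

Compound 1 `CC(=O)Nc1cnc2[nH]c(=O)n([C@H]3CC[C@@H](C(C)(C)C)CC3)c(=O)c2c1`: 15000 nM
Compound 2 `CC[C@H]1CC[C@@H](n2c(=O)[nH]c3ncc(NC(C)=O)cc3c2=O)CC1`: 48000 nM

Going by the values given here, in an ADME assay on L6 cells (Rattus norvegicus) for cytotoxicity, read by resazurin assay, with a stated time of 70 h (on this read-out higher numbers stand for an effect only at larger amounts of compound and lower numbers for an effect already at smaller amounts), compound 1 gives 15000 nM, the lower of the two numbers so far. Its nearest neighbour is compound 2, and the gap is a 3.2-fold higher number from compound 1 to compound 2 (0.51 log units; beyond the scatter). Compound 3 `CC(C)(C)[C@H]1CC[C@@H](n2c(=O)[nH]c3ncc(N)cc3c2=O)CC1` has not yet been measured. It differs from compound 1 in one place: hydrogen in place of acetyl on a nitrogen on an aromatic ring. This is hydrogen in place of acetyl on a nitrogen on an aromatic ring, or acetamido to amino. Among the compounds with values here, the only measured step is the one to compound 2, ethyl in place of tert-butyl on a saturated ring carbon. That step leaves the acetamido untouched, so it gives a rough size for one change and no direction for this one. Within the data shown here, no measured compound lacks the acetyl. In this assay no firm direction is therefore expected, and a shift of about that size either way would be unsurprising. The expected result is no change at the digits printed from compound 1 to compound 3 (within the scatter). For compound 3 the estimated value is 15000 nM, with an expected range of 5000 nM to 45000 nM.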

Compound 3, half-maximal effective concentration: 44000 nM
Beside the measured number, compound 3's estimate is 2.9-fold (0.47 log units) below it; low and high end bracket the measured number.
By their numbers in this assay, from the lowest: compound 1; then compounds 3 and 2 (each within the scatter of the next).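

In this assay, going by these compounds alone, the acetamido group turns out to matter: hydrogen in place of acetyl on this nitrogen gives a 2.9-fold higher number from compound 1 to compound 3 (0.47 log units; beyond the scatter), which gives this change a direction that the earlier compounds could not show. Together with a 3.2-fold higher number from compound 1 to compound 2 (0.51 log units; beyond the scatter), this leaves compound 1 with the lowest number, and each of the two single changes from it, one on the saturated ring carbon and one on the nitrogen, raises the number. Nothing available explains why the number rises when the acetyl leaves.

The compounds shown leave open whether the acetyl itself matters or whether another group on this nitrogen, such as propanoyl, methanesulfonyl or a simple methyl, would give the same number. They also leave open whether the acetamido to amino change would have a similar size with ethyl in place of tert-butyl on the saturated ring.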